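Extending the butyl chain of compound 2

The compounds below may be only part of what the source reports. "The series", "measured", "known", "first", "only" and "open" are said of these compounds alone.

In a functional assay on HL-60 cells (Homo sapiens) for cytotoxicity, read by WST assay, with a stated time of 48 h (a lower number here means that less compound is needed, a higher number that more compound is needed for the effect), compound 1 (`O=C1OC[C@H](Cc2ccccc2)[C@H]1Cc1ccccc1OC(F)(F)F`) gives 39000 nM and compound 2 (`CCCCOc1ccccc1C[C@H]1C(=O)OC[C@@H]1Cc1ccccc1`) gives 20000 nM. Going by the values given here, the only measured step, a 2.0-fold lower number from compound 1 to compound 2 (0.29 log units; within the scatter), puts butyl in place of trifluoromethyl on an oxygen, so these two values cannot be told apart. Compound 3 (`CCCCCCCOc1ccccc1C[C@H]1C(=O)OC[C@@H]1Cc1ccccc1`) extends that chain: propyl in place of hydrogen on a saturated chain carbon, four bonds along the chain from an oxygen on an aromatic ring. Among the compounds with values here, with only that one small step as a guide, no change beyond the scatter is expected, merely a slight lean towards a lower number, a 1.7-fold lower number from compound 2 to compound 3 (0.22 log units; within the scatter). For compound 3 the estimated value is 12000 nM, with an expected range of 5000 nM to 30000 nM.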

Compound 3, half-maximal effective concentration: 75000 nM
Compound 3: the middle estimate sits 6.3-fold (0.80 log units) below what was measured; measured number outside the range, above it.
By their numbers in this assay, from the lowest: compounds 2, 1 and 3 (each within the scatter of the next, the first and the last beyond it).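

Going from butyl to heptyl on this oxygen gives the first step beyond the scatter (a 3.8-fold higher number from compound 2 to compound 3 (0.57 log units; beyond the scatter)) in this assay, so the length of this chain can shift the number, and upwards rather than downwards. Set against trifluoromethyl (a 1.9-fold higher number from compound 1 to compound 3 (0.28 log units; within the scatter)), heptyl stays within the scatter, so those two cannot be told apart. Nothing measured here explains the rise. Still open, on these data alone, is where between butyl and heptyl the number starts to climb, which a pentyl or hexyl chain on this oxygen could show.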